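Removing a Trifluoromethyl Group and Cytotoxicity in Bovine Cells

The compounds below may be only part of what the source reports. "The series", "measured", "known", "first", "only" and "open" are said of these compounds alone.

Measured compounds:
compound 1 `CN(C)CCCN(/N=N/c1cc(F)ccc1F)c1ccccc1`: 25000 nM
compound 2 `Cc1c(/N=N/c2cccc(C(F)(F)F)c2)ccc(NC[C@@H]2CCCN3CCCC[C@H]23)c1C`: 52000 nM
compound 3 `CN(C)CCCN(/N=N/c1cc(F)ccc1F)c1cccc(C(F)(F)F)c1`: > 100000 nM

Of the compounds shown here, three have been tested in an ADME assay on MDBK cells (Bos taurus) for cytotoxicity, read by MTT assay, with a stated time of 96 h; a lower number here means that less compound is tolerated, a higher number that more compound is tolerated. Compound 1 gives 25000 nM and compound 2 gives 52000 nM. For compound 3 the result is only a limit, > 100000 nM. Compound 3 becomes compound 1 through (hydrogen in place of trifluoromethyl on an aromatic carbon), and the number falls: an at least 4.0-fold lower number from compound 3 to compound 1 (0.60 log units; beyond the scatter). The size of that step is open at one end due to the limit of > 100000 nM in this assay, at which 1 of the 3 values shown sits, where compound 3 sits. Compound 4 `Cc1c(/N=N/c2ccccc2)ccc(NC[C@@H]2CCCN3CCCC[C@H]23)c1C` arises from compound 2 through (hydrogen in place of trifluoromethyl on an aromatic carbon), the same change at the same place; how the core of compound 2 differs from that of compound 3 is not broken down here. Resting on the measured step of an at least 4.0-fold lower number from compound 3 to compound 1 (0.60 log units; beyond the scatter), a drop of similar size is expected from compound 2: a 3.7-fold lower number from compound 2 to compound 4 (0.57 log units; beyond the scatter). Compound 4 is therefore estimated at 14000 nM, between 5000 nM and 45000 nM.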

Compound 4, half-maximal cytotoxic concentration: 48000 nM
Compound 4: the middle estimate sits 3.4-fold (0.54 log units) below what was measured; the measured number lies above the stated range.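

On the second core, the same swap of trifluoromethyl for hydrogen gives a 1.1-fold lower number from compound 2 to compound 4 (0.03 log units; within the scatter) in this assay. The change therefore does not carry over with the same size from one core to the other, and the two steps differ: the same change on two cores in this assay, an at least 4.0-fold lower number (0.60 log units; beyond the scatter) from compound 3 to compound 1 and a 1.1-fold lower number (0.03 log units; within the scatter) from compound 2 to compound 4, at least 3.6-fold (0.56 log units) apart, beyond the scatter of two such steps For compound 3 the value of > 100000 nM is only a limit, and this single pair of cores does not show why the steps part or how the change would behave on any further core.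

The compounds shown leave open which part of the cores sets the size of the step. They also leave open how another group in the same place, such as a nitrile, a chlorine atom or a carboxylic acid, would read on each core.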